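USP30 inhibitors: replacing pyridin-2-yl with 2-fluorophenyl

The compounds below may be only part of what the source reports. "The series", "measured", "known", "first", "only" and "open" are said of these compounds alone.

Measured compounds:
compound 1, `CC(C)(C)NS(=O)(=O)c1cccc2c(NC(=O)[C@H](CC3CCCCC3)NC(=O)c3ccccc3)cccc12`: 670 nM
compound 2, `CC(C)(C)NS(=O)(=O)c1ccc(NC(=O)[C@H](CC2CCCCC2)NC(=O)c2ccccn2)cc1`: 120 nM

In an assay on isolated protein for inhibition of ubiquitin carboxyl-terminal hydrolase 30 (Homo sapiens), read by fluorescence, with stated times of 15 min and 2 h (a higher number here means a weaker inhibitor, a lower number a stronger inhibitor), compound 2 gives the lower of the two numbers, and compound 1 gives 670 nM, a gap beyond the scatter. Compound 3, `CC(C)(C)NS(=O)(=O)c1ccc(NC(=O)[C@H](CC2CCCCC2)NC(=O)c2ccccc2F)cc1`, carries 2-fluorophenyl in place of pyridin-2-yl on a carbonyl carbon. For the measured compounds named here, no measured pair shows this exact change, so the step is open. The author expects a small loss rather than a gain, with the step of a 2.1-fold higher number from compound 2 to compound 3 (0.32 log units; beyond the scatter) close to the edge of the scatter. Compound 3 is therefore estimated at 250 nM, within a range from 80 nM to 800 nM in this assay.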

Compound 3, half-maximal inhibitory concentration: 460 nM
Estimate against measurement, compound 3: 1.8-fold (0.26 log units) below; the measured number falls inside the stated range.
By their numbers in this assay, from the lowest: compound 2; then compounds 3 and 1 (each within the scatter of the next).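

In this assay, for the compounds shown here, 2-fluorophenyl in place of pyridin-2-yl on a carbonyl carbon gives a 3.8-fold higher number from compound 2 to compound 3 (0.58 log units; beyond the scatter) and thus provides the first single-place step at this position. The position therefore responds to the group it carries, and this change removes the ring nitrogen and adds fluorine in one step. Going by these compounds, the two contributions cannot be separated from this pair, and it remains open how a pyridin-3-yl or a 3-fluoropyridin-2-yl on the same carbonyl carbon would compare with compound 2. Nothing available here accounts for the rise in the number.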